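Removing the Fluorine: From Compound 1 to Compound 4

A few compounds are considered here, and "the series" means these few. Any claim that something is new, unique, unknown or untested is made for them only; others in the source may bear on it.

Compound 1 `Fc1ccc2ncc(-c3nn[nH]n3)cc2c1` stands in a functional assay on the whole organism (strain Sprague-Dawley) for inhibition, with Rattus norvegicus as the target (a higher number here means that more compound is needed for the effect, a lower number that less compound is needed), only at a limit, for in this assay compound 1 gives < 25 mg/kg, which is a limit of the assay and not a number (the limit of < 25 mg/kg in this assay, at which 1 of the 3 values shown sits). Compound 2 `Fc1cc(F)c2ncc(-c3nn[nH]n3)cc2c1` carries fluoro in place of hydrogen on an aromatic carbon relative to compound 1, and in this assay compound 2 gives 10 mg/kg. The step that the limit leaves unreadable from compound 1 to compound 2 therefore cannot be read in size. Compound 3 `Cc1cccc2cc(C(=O)O)cnc12` gives > 50 mg/kg, again a limit of the assay rather than a number (the limit of > 50 mg/kg in this assay, at which 1 of the 3 values shown sits).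

Compound 4 `c1ccc2ncc(-c3nn[nH]n3)cc2c1` is the unmeasured member, and it differs from compound 1 as follows: hydrogen in place of fluoro on an aromatic carbon. Among the measured compounds shown here, only one measured step touches this kind of change, the one from compound 1 to compound 2, and its size is hidden behind a limit. So nothing in the data fixes a direction. The change removes a single heavy atom, and the expectation is that compound 4 sits near compound 1 or somewhat weaker. The step of a number no lower from compound 1 to compound 4 (the limit leaves the size open) is expected to stay within the usual scatter. Compound 4 is estimated at 25 mg/kg in this assay, with a range from 10 mg/kg to 50 mg/kg.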

Compound 4, minimum effective dose: 10 mg/kg
Compound 4: the middle estimate sits 2.5-fold (0.40 log units) above what was measured, and the stated range covers the measured number.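

No new step can be read: compound 1 stands only at a limit of the assay and not at a number, so its comparison with compound 4 has no readable size: the limit of < 25 mg/kg in this assay, at which 1 of the 4 values shown sits.

The compounds shown leave open whether hydrogen in place of fluoro at this position changes the dose needed in this assay at all, and in which direction.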